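A few compounds are considered here, and "the series" means these few. Any claim that something is new, unique, unknown or untested is made for them only; others in the source may bear on it.

For the measured compounds named here, in an ADME assay on L929 cells (Mus musculus) for cytotoxicity, read by resazurin assay, with a stated time of 48 h (on this read-out lower numbers stand for higher toxicity in this test and higher numbers for lower toxicity in this test), compound 1 `C=Cn1c2ccc([N+](=O)[O-])cc2c(=O)n1Cc1ccccc1` gives 160000 nM and compound 2 `O=c1c2cc([N+](=O)[O-])ccc2n(CCCBr)n1Cc1ccccc1` gives 25200 nM, the lowest of the two numbers so far. Compound 3 `COC(=O)CCn1c2ccc([N+](=O)[O-])cc2c(=O)n1Cc1ccccc1` differs from compound 2 by methoxycarbonyl in place of bromomethyl on a saturated chain carbon, two bonds along the chain from an aromatic nitrogen. Going by the values given here, the only measured step bearing on this is the modest 6.3-fold lower number from compound 1 to compound 2 (0.80 log units; beyond the scatter), which introduced the 3-bromopropyl group now being changed. A step of similar or smaller size towards a higher number is therefore expected in this assay. The expected change is a 2.4-fold higher number from compound 2 to compound 3 (0.38 log units; beyond the scatter). For compound 3, the estimate is 60000 nM, with a range of 22000 nM to 160000 nM.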

Compound 3, concentration lethal to 50% of the cells: > 256000 nM
Compound 3 was reported as a limit; the forecaster's own chance of this, stated with the estimate: 10%; middle value at least 4.2-fold (0.63 log units) from the limit.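

Compound 3 stands as a limit of the assay, not as a number: the limit of > 256000 nM in this assay, at which 1 of the 3 values shown sits. Methoxycarbonyl in place of bromomethyl gives an at least 10-fold higher number from compound 2 to compound 3 (1.00 log units; beyond the scatter), so the low number of compound 2 is tied to the 3-bromopropyl group and is not shared by the 2-(methoxycarbonyl)ethyl group at this position. Against vinyl, the change gives an at least 1.6-fold higher number from compound 1 to compound 3 (0.20 log units; that floor lies within the scatter), so no order between these two groups can be claimed from that floor.

Open, on these data alone, is how far the high number of compound 3 extends to other chain ends. A carboxylic acid, an amine or a plain propyl chain could show whether bromine alone sets the low number of compound 2.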